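Replacing the phenol of compound 1 with a carboxypiperidine

The source may hold more compounds than are shown below. What is called first, only, known or untested is meant among the compounds shown, and "the series" means these compounds.

Within the data shown here, compound 1 `CCC(C)(C)Cc1c[nH]c(CCc2ccc(-c3ccccc3O)cc2)n1` gives the higher of the two numbers measured so far in a functional assay for agonist activity at Bombesin receptor subtype-3 (Mus musculus) (on this read-out higher numbers stand for an effect only at larger amounts of compound and lower numbers for an effect already at smaller amounts), with 34 nM. Among the measured compounds shown here, its nearest neighbour is compound 2 `CCC(C)(C)Cc1c[nH]c(CCc2ccc(-c3ccccc3OCc3nc(N)n[nH]3)cc2)n1`, which in this assay gives 4.6 nM; the only measured step, a 7.4-fold lower number from compound 1 to compound 2 (0.87 log units; beyond the scatter), comes from extending the phenol oxygen with a triazolylmethyl group.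

Compound 3 `CCC(C)(C)Cc1c[nH]c(CCc2ccc(N3CCCC[C@@H]3C(=O)O)cc2)n1` changes compound 1 at a different place: 2-carboxypiperidin-1-yl in place of 2-hydroxyphenyl on an aromatic carbon. For the measured compounds named here, the whole hydroxyphenyl is exchanged for a saturated ring carrying an acid, so the measured step, which only builds on the retained phenol, does not bear directly on it; no step from compound 2 is known either. Nothing in the series shows what removing the hydroxyphenyl does, so the expectation for compound 3 in this assay is kept near compound 1 with wide uncertainty, a 1.8-fold higher number from compound 1 to compound 3 (0.25 log units; within the scatter). Compound 3 is estimated at 60 nM, within 8 nM to 450 nM.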

Compound 3, half-maximal effective concentration: 12 nM
Beside the measured number, compound 3's estimate is 5.0-fold (0.70 log units) above it, within the range that was stated.
By their numbers in this assay, from the lowest: compound 2; then compound 3; then compound 1.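

In this assay the 2-hydroxyphenyl is not needed for the effect at this position: 2-carboxypiperidin-1-yl in its place gives a 2.8-fold lower number from compound 1 to compound 3 (0.45 log units; beyond the scatter). The earlier step kept the phenol oxygen and built on it, whereas this one shows that a six-membered non-aromatic ring with a hetero atom is accepted on this aromatic carbon in place of the six-membered aromatic ring of carbon only. Nothing available bears on why the number moves in this direction.

Which part of the entering group goes with the step remains open: the carboxylic acid, the saturated ring or the defined stereocentre. A plain piperidin-1-yl, a methyl ester in place of the carboxylic acid, or the opposite stereocentre would separate these.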